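A few compounds are considered here, and "the series" means these few. Any claim that something is new, unique, unknown or untested is made for them only; others in the source may bear on it.

Measured in an ADME assay on cells (Homo sapiens) for cytotoxicity, read by resazurin assay, with a stated time of 5 days; a higher number here means that more compound is tolerated, a lower number that less compound is tolerated:

- Compound 1 `COc1ccc(-c2nc(CNc3cccc(Cl)c3)nc3ccsc23)cn1`: > 50000 nM
- Compound 2 `O=S(=O)(Cc1nc(-c2ccnc(Cl)c2)c2sccc2n1)c1cccc(Cl)c1`: 63000 nM

The entry for compound 1 is a limit of the assay, not a number. Among the compounds with values here, that leaves compound 2, at 63000 nM, with the only actual number so far, and it sits among well-tolerated values.

Compound 3 `COc1ccc(Oc2nc(CS(=O)(=O)c3cccc(Cl)c3)nc3ccsc23)cc1` keeps the rest of compound 2 but carries 4-methoxyphenoxy in place of 2-chloropyridin-4-yl on an aromatic carbon. Within the data shown here, no two measured compounds differ in just one place, so there is no direct guide to this change. The expected 1.8-fold lower number from compound 2 to compound 3 (0.26 log units; within the scatter) is small, within the usual scatter of repeats. Compound 3 is estimated at 35000 nM, with an expected range of 10000 nM to 80000 nM.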

Compound 3, half-maximal cytotoxic concentration: > 50000 nM
Compound 3 was reported as a limit; the forecaster's own chance of this, stated with the estimate: 35%; middle value at least 1.4-fold (0.15 log units) away from the limit.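

In this assay, within the data shown here, compound 3 gives > 50000 nM, which is a limit and not a number, so no step between compound 2 and compound 3 can be read. The compounds shown leave open how far 4-methoxyphenoxy in place of 2-chloropyridin-4-yl changes the tolerated concentration: the limit of > 50000 nM in this assay, at which 2 of the 3 values shown sit.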